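The source may hold more compounds than are shown below. What is called first, only, known or untested is meant among the compounds shown, and "the series" means these compounds.

In a functional assay on NCI-H460 cells (Homo sapiens) for inhibition, read by MTT assay, with a stated time of 4 days (on this read-out lower numbers stand for stronger inhibition and higher numbers for weaker inhibition), three compounds sharing one core have so far yielded no actual number. Compound 1 `COc1cc(NC(C)CCCNC(=O)NN)c2ncccc2c1` gives > 100000 nM, which is a limit of the assay and not a number. Compound 2 `COc1cc(NC(C)CCCNC(=O)NNC(=O)N(CCO)CCO)c2ncccc2c1` gives > 100000 nM, again a limit. Compound 3 `COc1cc(NC(C)CCCNC(=O)NNC(=O)NCCCO)c2ncccc2c1` gives > 100000 nM, also a limit. Compound 3 therefore stands with the other two, and the whole set rests on (the limit of > 100000 nM in this assay, at which 3 of the 3 values shown sit).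

The next structure, compound 4 `COc1cc(NC(C)CCCNC(=O)Nc2ccc(Cl)c(C(F)(F)F)c2)c2ncccc2c1`, makes a much larger change: 4-chloro-3-(trifluoromethyl)phenyl in place of ((3-hydroxypropyl)carbamoyl)amino on an amide-type nitrogen. In words, this is 4-chloro-3-(trifluoromethyl)phenyl in place of ((3-hydroxypropyl)carbamoyl)amino on an amide-type nitrogen.

The measured steps closest to this change are a step that the two limits leave unreadable from compound 1 to compound 3 and a step that the two limits leave unreadable from compound 2 to compound 3, and a step that the two limits leave unreadable from compound 1 to compound 2 is no more informative. None of them supplies a size to carry over, and none tests an aromatic group at this place. The expectation is therefore a loose one: an at least 12-fold lower number from compound 3 to compound 4 (1.09 log units; beyond the scatter), toward stronger inhibition, with a result at the limit still possible. For compound 4 the estimated value is 8000 nM, with an expected range of 1500 nM to 40000 nM.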

Compound 4, half-maximal inhibitory concentration: 28000 nM
Beside the measured number, compound 4's estimate is 3.5-fold (0.54 log units) below it; the range from low to high includes it.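

In this assay, the amide-type nitrogen now yields a readable change: 4-chloro-3-(trifluoromethyl)phenyl in place of ((3-hydroxypropyl)carbamoyl)amino gives an at least 3.5-fold lower number from compound 3 to compound 4 (0.55 log units; beyond the scatter). The same group gives an at least 3.5-fold lower number from compound 2 to compound 4 (0.55 log units; beyond the scatter) in place of (bis(2-hydroxyethyl)carbamoyl)amino, and an at least 3.5-fold lower number from compound 1 to compound 4 (0.55 log units; beyond the scatter) in place of amino. The steps among compound 1, compound 2 and compound 3 cannot be read, and the three steps to the new compound give only a minimum size, because the three earlier compounds share one limit: the limit of > 100000 nM in this assay, at which 3 of the 4 values shown sit.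

The compounds shown leave open how much of this change comes from the aromatic ring itself and how much from its chloro and trifluoromethyl groups. A plain phenyl at this nitrogen, or a phenyl carrying only chloro or only trifluoromethyl, would separate those contributions.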